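The compounds below may be only part of what the source reports. "The series", "measured", "known", "first", "only" and "open" are said of these compounds alone.

Compound 1 `COc1ccc(CN2CCC(C(=O)Nc3cc(Cl)c(N)cc3OC)CC2)cc1` gives 0.9 mg/kg in a functional assay on the whole organism for antagonist activity, with Mus musculus as the target; a higher number here means that more compound is needed for the effect, a lower number that less compound is needed. Compound 2 `COc1cc(N)c(Cl)cc1NC(=O)C1CCN(CC2CCCC2)CC1` gives only a limit, > 10 mg/kg. Compound 3 `COc1cc(N)c(Cl)cc1NC(=O)C1CCN(Cc2ccc([N+](=O)[O-])cc2)CC1` also gives only a limit, > 4 mg/kg.

Compound 3 therefore stands at a limit of this assay, (the limit of > 4 mg/kg in this assay, at which 1 of the 3 values shown sits), and its place among the three is not fixed. Compound 4 `COc1cc(N)c(Cl)cc1NC(=O)C1CCN(Cc2ccccc2F)CC1` differs from compound 3 in one place: 2-fluorophenyl in place of 4-nitrophenyl on a saturated chain carbon bound to an amine nitrogen in a ring. Within the data shown here, two measured steps bear on this change. The first is an at least 4.4-fold higher number from compound 1 to compound 3 (0.64 log units; beyond the scatter); the second is a step that the two limits leave unreadable from compound 2 to compound 3. Taking the nitro group away again is expected to bring the number back down toward that of compound 1, 0.9 mg/kg. The expected step is an at least 2.0-fold lower number from compound 3 to compound 4 (0.30 log units; that floor lies within the scatter). Compound 4 is thus estimated at 2 mg/kg, in a range from 0.7 mg/kg to 6 mg/kg.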

Compound 4, dose for half-maximal effect: > 4 mg/kg
Compound 4: a limit, no number; the forecaster's own chance of this, stated with the estimate: 25%; middle value at least 2.0-fold (0.30 log units) from the limit.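

Putting 2-fluorophenyl in place of 4-methoxyphenyl at this place gives an at least 4.4-fold higher number from compound 1 to compound 4 (0.64 log units; beyond the scatter), so losing the nitro group does not by itself bring the number back toward that of compound 1. Among the four compounds, only compound 1, with 4-methoxyphenyl, gives a number rather than a limit. Compound 4 gives only a limit in this assay, the same one as compound 3, so the steps to compound 4 from compound 2 and compound 3 cannot be read: the limit of > 4 mg/kg in this assay, at which 2 of the 4 values shown sit.

Where the true number of compound 4 lies stays open. So does whether a plain phenyl or a 4-ethoxyphenyl group at this place would give a number rather than a limit.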